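Trimming the Ether Substituent From Benzyl to Ethyl

A few compounds are considered here, and "the series" means these few. Any claim that something is new, unique, unknown or untested is made for them only; others in the source may bear on it.

Three measured compounds share one core and differ only in the group carried through an oxygen on the aromatic ring. In a functional assay on BGC-823 cells (Homo sapiens) for cytotoxicity, read by MTT assay, with a stated time of 48 h (a lower number here means a stronger inhibitor, a higher number a weaker inhibitor), compound 1 `CCCCCCCCOc1ccc2c(Cl)ccnc2c1` gives 4300 nM. Compound 2 `CCCCCCOc1ccc2c(Cl)ccnc2c1` gives 2380 nM, and the step of a 1.8-fold lower number from compound 1 to compound 2 (0.26 log units; within the scatter) shows that removing part of the chain changed little. Compound 3 `Clc1ccnc2cc(OCc3ccccc3)ccc12` gives 5170 nM, the highest of the three numbers; it sits within the scatter of compound 1, while the step of a 2.2-fold higher number from compound 2 to compound 3 (0.34 log units; beyond the scatter) is modest but beyond it. Compound 4 `CCOc1ccc2c(Cl)ccnc2c1` is not yet measured. Its change from compound 3 is methyl in place of phenyl on a saturated chain carbon bound to an oxygen on an aromatic ring. The steps of a 1.8-fold lower number from compound 1 to compound 2 (0.26 log units; within the scatter) and a 2.2-fold higher number from compound 2 to compound 3 (0.34 log units; beyond the scatter) both concern this same position and were small, so the expected step of a 1.2-fold higher number from compound 3 to compound 4 (0.06 log units; within the scatter) is also small, likely within the scatter or slightly toward a higher number. Compound 4 is therefore expected to give about 6000 nM, within a range from 2500 nM to 15000 nM.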

Compound 4, half-maximal inhibitory concentration: 3910 nM
Estimate against measurement, compound 4: 1.5-fold (0.19 log units) above, and the stated range covers the measured number.
By their numbers in this assay, from the lowest: compounds 2, 4, 1 and 3 (each within the scatter of the next, the first and the last beyond it).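

Replacing phenyl with methyl gives a 1.3-fold lower number from compound 3 to compound 4 (0.12 log units; within the scatter), so in this assay removing the aromatic ring from this position leaves the number within the scatter. Compound 4 also extends the test to a much shorter straight chain: a 1.6-fold higher number from compound 2 to compound 4 (0.22 log units; within the scatter) and a 1.1-fold lower number from compound 1 to compound 4 (0.04 log units; within the scatter) both stay within the scatter, so hydrogen in place of butyl or hexyl does not separate these compounds. Among all four, only a 2.2-fold higher number from compound 2 to compound 3 (0.34 log units; beyond the scatter) lies beyond the scatter, and nothing measured here explains that modest gap.

Every group shown on this oxygen contains only carbon and hydrogen, so it remains open whether an amine or a carboxylic acid at this place would shift the number further. From the compounds shown here alone, a chain longer than that of compound 1 and a substituted phenyl ring also remain untested in this set.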